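Changing the Amide Aryl Group on a Shared Core

A few compounds are considered here, and "the series" means these few. Any claim that something is new, unique, unknown or untested is made for them only; others in the source may bear on it.

Three compounds share one core and differ only in the aromatic group attached to the amide carbonyl. Compound 1 `CN1[C@@H]2c3[nH]c4ccccc4c3C[C@H]1[C@H](C#N)N1[C@@H](CNC(=O)c3cccc(C(F)(F)F)c3)c3[nH]c4ccccc4c3C[C@@H]21` carries a 3-(trifluoromethyl)phenyl group there, and in a functional assay on A2780 cells (Homo sapiens) for cytotoxicity, read by MTT assay, with a stated time of 72 h (a higher number here means a weaker inhibitor, a lower number a stronger inhibitor), compound 1 gives 210 nM. Compound 2 `COc1ccc(C(=O)NC[C@H]2c3[nH]c4ccccc4c3C[C@H]3[C@H]4c5[nH]c6ccccc6c5C[C@@H]([C@H](C#N)N23)N4C)cc1` carries a 4-methoxyphenyl group, and in this assay compound 2 gives 320 nM. Compound 3 `CN1[C@@H]2c3[nH]c4ccccc4c3C[C@H]1[C@H](C#N)N1[C@@H](CNC(=O)c3ccc(F)cc3)c3[nH]c4ccccc4c3C[C@@H]21` carries a 4-fluorophenyl group; in this assay compound 3 gives 250 nM, which places it second highest of the three numbers, with compound 1 nearest and compound 2 furthest, every gap lying within the scatter. The measured steps read: a 1.5-fold higher number from compound 1 to compound 2 (0.18 log units; within the scatter), a 1.2-fold higher number from compound 1 to compound 3 (0.08 log units; within the scatter) and a 1.3-fold lower number from compound 2 to compound 3 (0.11 log units; within the scatter).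

Compound 4 `CN1[C@@H]2c3[nH]c4ccccc4c3C[C@H]1[C@H](C#N)N1[C@@H](CNC(=O)c3cccc4c3CCCC4)c3[nH]c4ccccc4c3C[C@@H]21` has not yet been measured. It differs from compound 3 in one place: 1,2,3,4-tetrahydronaphthalen-5-yl in place of 4-fluorophenyl on a carbonyl carbon. Among the measured compounds shown here, no measured step covers the entry of a fused second ring, so the closest guide is that all three measured changes on the same carbonyl carbon stayed within the scatter. On that basis compound 4 is expected to show little movement, estimated as a 1.2-fold higher number from compound 3 to compound 4 (0.08 log units; within the scatter). The value expected for compound 4 in this assay is therefore 300 nM, with a range from 120 nM to 750 nM.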

Compound 4, half-maximal inhibitory concentration: 810 nM
Compound 4: middle estimate off by 2.7-fold (0.43 log units), on the low side; measured number above the stated range.
By their numbers in this assay, from the lowest: compounds 1, 3 and 2 (each within the scatter of the next); then compound 4.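

The amide aryl position is not indifferent to every change: in this assay the three compounds with a single aromatic ring lie within the scatter of one another, yet the measurements show a 3.2-fold higher number from compound 3 to compound 4 (0.51 log units; beyond the scatter) and a 2.5-fold higher number from compound 2 to compound 4 (0.40 log units; beyond the scatter) and also a 3.9-fold higher number from compound 1 to compound 4 (0.59 log units; beyond the scatter) on entry of the 1,2,3,4-tetrahydronaphthalen-5-yl group. All three steps are modest and point the same way, towards a weaker inhibitor, so among these compounds only the group with a non-aromatic ring added to its aromatic ring, carrying 10 heavy atoms against the 7 of 4-fluorophenyl, moves the number beyond the scatter. The data give the direction and size of this change, but nothing available here accounts for it.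

The compounds shown leave open whether the loss follows from the added non-aromatic ring itself or from the extra carbon atoms, however they are arranged. An unsubstituted phenyl group, a phenyl group carrying a longer alkyl chain, or one carrying an amine or a carboxylic acid would show how far this position accepts other changes.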